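The compounds below may be only part of what the source reports. "The series", "measured", "known", "first", "only" and "open" are said of these compounds alone.

The measured compounds:
compound 1, `Cc1cc(C)cc(NC(=O)CN2CCC(c3cccc[n+]3[O-])CC2)c1`, 76%
compound 2, `C=Cc1cccc(C(=O)NCN2CCC(c3cccc[n+]3[O-])CC2)c1`, 63%
compound 3, `O=C(NCN1CCC(c2cccc[n+]2[O-])CC1)c1cnccc1Cl`, 44%

All three share the same core and were tested in a functional assay on HEK293 cells for agonist activity at D(4) dopamine receptor (Homo sapiens), read by FLIPR; on this read-out higher numbers stand for larger maximal responses and lower numbers for smaller maximal responses. Compound 1 stands highest of the three readings; compound 2 is the nearest to it and compound 3 the furthest, both beyond the usual scatter. Within the data shown here, the only step between two compounds that differ in a single place is a number 19 percentage points lower from compound 2 to compound 3 (beyond the scatter), which exchanges the group attached to the carbonyl carbon.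

Compound 4, `O=C(CN1CCC(c2cccc[n+]2[O-])CC1)Nc1cc(Cl)cc(Cl)c1`, differs from compound 1 in one place: 3,5-dichlorophenyl in place of 3,5-dimethylphenyl on an amide-type nitrogen. This change sits on the amide-type nitrogen, not on the carbonyl carbon, and the two groups involved are the same size, so the measured step between compound 2 and compound 3 bears on it only loosely. Among the measured compounds shown here, no measured pair shows a methyl-bearing phenyl traded for a chlorine-bearing one, so there is no direct guide. Given this, the expected change in this assay is small, probably within the scatter, with a slight lean downward in case the trade costs some efficacy.

The estimate for compound 4 is therefore 70%, in the range 50% to 88%, which means a step of a number 6 percentage points lower from compound 1 to compound 4 (within the scatter) is expected.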

Compound 4, largest response reached (reported as efficacy), in percent of the reference or control that the assay uses: 68%
For compound 4 the middle estimate is 2 percentage points above the measured one, within the range that was stated.
By their numbers in this assay, from the lowest: compound 3; then compounds 2, 4 and 1 (each within the scatter of the next, the first and the last beyond it).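

In this assay, the trade of 3,5-dimethylphenyl for 3,5-dichlorophenyl on an amide-type nitrogen gives a number 8 percentage points lower from compound 1 to compound 4 (within the scatter), so the maximal response holds across this change. Among these compounds, this is the first view of this position, since the only earlier step concerned a different place, the group on a carbonyl carbon. The two groups match in their counts of heavy atoms, hydrogen-bond donors and hydrogen-bond acceptors, and both carry one six-membered aromatic ring of carbon only, yet nothing measured here says why the response holds across the trade.

Among the compounds shown here, this is one pair, so it shows only that these two groups cannot be told apart at this position, not that any group would do there. As far as these compounds go, whether the response would also hold with an amine or a carboxylic acid on the phenyl ring in place of the two chlorines, or with a plain phenyl carrying no such groups, stays open.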